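A Fluorine for Bromine on the Benzyl Group

The compounds below may be only part of what the source reports. "The series", "measured", "known", "first", "only" and "open" are said of these compounds alone.

Compound 2 `O=C(/C=C/c1ccc(OCc2cn(Cc3ccc(Br)cc3)nn2)cc1)c1ccc([N+](=O)[O-])cc1` holds the lowest of the two numbers recorded in a functional assay on A549 cells (Homo sapiens) for inhibition, read by MTT assay, with a stated time of 48 h, tested at 10 uM; on this read-out lower numbers stand for less inhibition of growth and higher numbers for more inhibition of growth at the one concentration tested: there compound 2 gives 18%, while compound 1 `O=C(/C=C/c1ccc(OCc2cn(Cc3cccc(Br)c3)nn2)cc1)c1ccc([N+](=O)[O-])cc1` gives 28%. Going by the values given here, the single measured step, a number 10 percentage points lower from compound 1 to compound 2 (within the scatter), shifted the bromine on the same phenyl and stayed within the scatter. Compound 3 `O=C(/C=C/c1ccc(OCc2cn(Cc3ccccc3F)nn2)cc1)c1ccc([N+](=O)[O-])cc1` carries 2-fluorophenyl in place of 4-bromophenyl on a saturated chain carbon bound to an aromatic nitrogen. Among the compounds with values here, that one step is the only guide, and it gives no reason to expect a move beyond the scatter, so the expected step for compound 3 is a number 4 percentage points higher from compound 2 to compound 3 (within the scatter). Compound 3 is therefore estimated at 22%, with a range from 8% to 38%.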

Compound 3, percent growth inhibition at one concentration: 43%
Compound 3: the middle estimate sits 21 percentage points below what was measured; measured number outside the range, above it.
By their numbers in this assay, from the lowest: compounds 2 and 1 (each within the scatter of the next); then compound 3.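

With 2-fluorophenyl on the saturated chain carbon bound to an aromatic nitrogen, the read-out in this assay shows a number 25 percentage points higher from compound 2 to compound 3 (beyond the scatter) and also a number 15 percentage points higher from compound 1 to compound 3 (beyond the scatter), so this place can carry a change beyond the scatter, which moving the bromine on the phenyl did not show. The pattern holds for both bromophenyl compounds. No evidence available here bears on the reason for this result.

The halogen and its place on the phenyl change together, so their shares remain apart from reach. From the compounds shown here alone, how an amine or a carboxylic acid at this place would read also stays open.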